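A Methylphenyl Amide Weighed Against the Pyridyl Benchmark

A few compounds are considered here, and "the series" means these few. Any claim that something is new, unique, unknown or untested is made for them only; others in the source may bear on it.

Compound 1 `O=C(Nc1cc(-c2ccccc2)nn1-c1ccccc1)c1ccccn1` carries a (pyridin-2-yl)carbonyl group on the amide nitrogen of the shared core. Among the compounds with values here, in an assay on CHO cells with metabotropic glutamate receptor 5 (Homo sapiens) as the target (on this read-out higher numbers stand for an effect only at larger amounts of compound and lower numbers for an effect already at smaller amounts), compound 1 gives 290 nM, the highest of the two numbers measured so far. Within the data shown here, its nearest neighbour is compound 2 `O=C(Nc1cc(-c2ccccc2)nn1-c1ccccc1)c1cccc(F)c1`, which in this assay gives 20 nM; the step between them is the only measured step that bears on the present question, and it is large.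

Compound 3 `Cc1cccc(C(=O)Nc2cc(-c3ccccc3)nn2-c2ccccc2)c1` has not yet been measured in this assay. It differs from compound 1 in one place: 3-methylphenyl in place of pyridin-2-yl on a carbonyl carbon. Among the measured compounds shown here, the change resembles the one leading to compound 2, where 3-fluorophenyl took the place of pyridin-2-yl on the carbonyl carbon and the number fell sharply, as a 15-fold lower number from compound 1 to compound 2 (1.16 log units; beyond the scatter) shows. Compound 3 is therefore expected to give a lower number than compound 1, with an estimated step of an 8.3-fold lower number from compound 1 to compound 3 (0.92 log units; beyond the scatter). The estimate for compound 3 in this assay is 35 nM, expected to fall between 10 nM and 120 nM.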

Compound 3, half-maximal effective concentration: 90 nM
Compound 3: middle estimate off by 2.6-fold (0.41 log units), on the low side; measured number inside the range.
By their numbers in this assay, from the lowest: compound 2; then compound 3; then compound 1.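

In this assay, 3-methylphenyl in place of pyridin-2-yl on a carbonyl carbon also lowers the number, with a 3.2-fold lower number from compound 1 to compound 3 (0.51 log units; beyond the scatter) on the amide of the shared core. The fall seen with 3-fluorophenyl is thus not unique to that group, and among the three compounds shown, both groups with a ring of carbon only stand lower than pyridin-2-yl. The group on that ring also matters, since methyl in place of fluoro on an aromatic carbon gives a 4.5-fold higher number from compound 2 to compound 3 (0.65 log units; beyond the scatter) and so gives back part of the ground gained, although nothing available explains either step.

The compounds shown leave open how much of the fall belongs to the exchange of the pyridin-2-yl ring for a ring of carbon only and how much to the group that ring carries, a question that a plain phenyl on the carbonyl carbon would address. They also leave open how a chloro, methoxy or nitrile group would stand in place of the methyl or the fluoro, and so whether any group on this ring gives a lower number than the fluoro of compound 2.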